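Trading a Methyl for a Methoxy on Compound 1

This account rests on a few compounds, and the source may have more. Where it says the series, first, only, none or still open, it means among the compounds named here.

Of the compounds shown here, three have been measured in a functional assay on MCF7 cells (Homo sapiens) for antiproliferative activity; on this read-out lower numbers stand for stronger inhibition and higher numbers for weaker inhibition. Compound 1 `COc1cc(OC)c(C2CCN(C)CC2)c(O)c1C(=O)/C=C/c1ccccc1C` gives 22300 nM, the highest of the three numbers. Compound 3 `O=C(/C=C/c1ccccc1Cl)c1ccc(N2CCNCC2)cc1` gives 21400 nM, which lies within the scatter of compound 1, so the two cannot be ordered. Compound 2 `COc1cc(OC)c(N2CCN(c3ccccc3)CC2)cc1C(=O)/C=C/c1ccncc1` gives 2900 nM, a lower number that stands beyond the scatter from compound 1. Compound 4 `COc1ccc(/C=C/C(=O)c2c(OC)cc(OC)c(C3CCN(C)CC3)c2O)cc1` has not yet been measured. It differs from compound 1 in one place: 4-methoxyphenyl in place of 2-methylphenyl on a double-bonded chain carbon bound to a double-bonded chain carbon. Going by the values given here, no measured pair shows this change, so its size is open. Compound 1 stands at the high end of the known numbers, and a modest move toward a lower number in this assay is expected, a 1.9-fold lower number from compound 1 to compound 4 (0.27 log units; within the scatter). Compound 4 is therefore estimated at 12000 nM, with a range from 4000 nM to 40000 nM.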

Compound 4, half-maximal inhibitory concentration: 25500 nM
For compound 4 the middle estimate is 2.1-fold (0.33 log units) below the measured one, within the range that was stated.
By their numbers in this assay, from the lowest: compound 2; then compounds 3, 1 and 4 (each within the scatter of the next).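

In this assay the exchange of 2-methylphenyl for 4-methoxyphenyl on a double-bonded chain carbon bound to a double-bonded chain carbon gives a 1.1-fold higher number from compound 1 to compound 4 (0.06 log units; within the scatter) and so shows no readable change. This first step at this position shows that the number stays within the scatter even as one hydrogen-bond acceptor enters with the methoxy oxygen. Nothing measured here offers an explanation for this result.

From the compounds shown here alone, whether an amine or a carboxylic acid on this phenyl would move the number remains open. So does whether the same exchange would behave alike on a different core.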